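The source may hold more compounds than are shown below. What is called first, only, known or untested is meant among the compounds shown, and "the series" means these compounds.

Measured so far:
compound 1 `Cc1cccc2nc(-c3cccc(NC(=O)CCc4ccccc4)c3)[nH]c12` — 60000 nM
compound 2 `Cc1cccc2nc(-c3cccc(NC(=O)CCCc4ccccc4)c3)[nH]c12` — 38600 nM
compound 3 `O=C(CCCc1ccccc1)Nc1ccc(-c2nc3ccccc3[nH]2)cc1` — > 100000 nM

In an assay on cells for inhibition of matrix metalloproteinase-9 (Homo sapiens), read by fluorescence, with stated times of 15 min and 4 h (a higher number here means a weaker inhibitor, a lower number a stronger inhibitor), compound 2 gives 38600 nM and compound 1 gives 60000 nM. The change between them, (phenyl in place of benzyl on a saturated chain carbon, two bonds along the chain from a carbonyl carbon), gives a 1.6-fold higher number from compound 2 to compound 1 (0.19 log units; within the scatter). Compound 3 carries a different core; the difference between the two cores is not broken down here. In this assay compound 3 sits at the limit of > 100000 nM in this assay, at which 1 of the 3 values shown sits, which is a limit of the assay and not a number. Compound 4 `O=C(CCc1ccccc1)Nc1ccc(-c2nc3ccccc3[nH]2)cc1` is not yet measured. It differs from compound 3 by phenyl in place of benzyl on a saturated chain carbon, two bonds along the chain from a carbonyl carbon, the same change as that from compound 2 to compound 1. Resting on that measured step, compound 4 is expected to give a step that the limit leaves unreadable from compound 3 to compound 4. Because compound 3 already sits at the limit of > 100000 nM in this assay, at which 1 of the 3 values shown sits, compound 4 is estimated near 150000 nM, most likely reported as a limit, within 60000 nM to 400000 nM.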

Compound 4, half-maximal inhibitory concentration: 29000 nM
Estimate against measurement, compound 4: 5.2-fold (0.71 log units) above, and the stated range ends above it.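

In this assay, phenyl in place of benzyl on the saturated chain carbon gives an at least 3.4-fold lower number from compound 3 to compound 4 (0.53 log units; beyond the scatter). Compound 3 stands at > 100000 nM, which is a limit of the assay and not a number. The change therefore does not carry over at one size from one core to the other, although this rests on a single pair on each core and does not show which difference between the cores goes with the gap: the same change on two cores in this assay, a 1.6-fold higher number (0.19 log units; within the scatter) from compound 2 to compound 1 and an at least 3.4-fold lower number (0.53 log units; beyond the scatter) from compound 3 to compound 4, at least 5.3-fold (0.72 log units) apart, beyond the scatter of two such steps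

The compounds shown leave open how a longer chain would behave on either core. They also leave open what an amine or a carboxylic acid in place of the phenyl would give.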